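Methyl in Place of Methoxy on Compound 2

The compounds below may be only part of what the source reports. "The series", "measured", "known", "first", "only" and "open" are said of these compounds alone.

In an ADME assay on L1210/0 cells (Mus musculus) for cytotoxicity, with a stated time of 48 h (on this read-out lower numbers stand for stronger inhibition and higher numbers for weaker inhibition), compound 1 (`COc1ccc(-c2ncnc3c2ncn3C[C@@H]2C[C@H](CO)c3ccccc32)cc1`) gives 17600 nM while compound 2 (`COc1ccc(C(=O)/C=C/c2cc(=O)[nH]c(=O)n2COCCO)cc1`) gives 33500 nM and the two numbers lie within the usual scatter of each other. Compound 3 (`Cc1ccc(C(=O)/C=C/c2cc(=O)[nH]c(=O)n2COCCO)cc1`) differs from compound 2 by a single change (methyl in place of methoxy on an aromatic carbon) with methyl in place of methoxy on an aromatic carbon. Among the compounds with values here, no measured pair shows this change, so no shift beyond the scatter is expected in either direction. The expected step is a 1.1-fold lower number from compound 2 to compound 3 (0.05 log units; within the scatter) and it stays within the scatter. For compound 3 the estimate is 30000 nM with an expected range from 14000 nM to 65000 nM on this read-out.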

Compound 3, half-maximal inhibitory concentration: 27900 nM
For compound 3 the middle estimate is 1.1-fold (0.03 log units) above the measured one, and the stated range covers the measured number.
By their numbers in this assay, from the lowest: compounds 1, 3 and 2 (each within the scatter of the next).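

In this assay, within the data shown here, the change from 4-methoxyphenyl to 4-methylphenyl gives a 1.2-fold lower number from compound 2 to compound 3 (0.08 log units; within the scatter), so this pair offers the first direct reading at this position, and the two compounds cannot be told apart. The methoxy oxygen, counted as one hydrogen-bond acceptor, is therefore not needed to keep the number in this range. Nothing measured here explains this result.

Still open, as far as these compounds go, is how an amine, a carboxylic acid or a longer chain would read at this position. Also open, from the compounds shown here alone, is whether the same change reads alike on the core of compound 1, which carries 4-methoxyphenyl too.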